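Aryl Swap on the Triazole Nitrogen, at the Assay Limit

This account rests on a few compounds, and the source may have more. Where it says the series, first, only, none or still open, it means among the compounds named here.

Compound 3 `N#CC1=C(N)Oc2c(N)cc3nc4ccccc4nc3c2C12C(=O)N(Cc1cnnn1-c1cccc(Br)c1)c1ccccc12` stands at the edge of what can be read. In a functional assay on HepG2 cells (Homo sapiens) for antiproliferative activity, read by MTT assay, with a stated time of 48 h (a lower number here means a stronger inhibitor, a higher number a weaker inhibitor), compound 3 gives > 50000 nM, which is a limit rather than a number. Its two companions are placed no differently. Compound 1 `Cc1cccc(-n2nncc2CN2C(=O)C3(C(C#N)=C(N)Oc4c3c3nc5ccccc5nc3c3ccccc43)c3ccccc32)c1` reaches only a limit, giving > 50000 nM in this assay. Compound 2 `N#CC1=C(N)Oc2c(c3nc4ccccc4nc3c3ccccc23)C12C(=O)N(Cc1cnnn1-c1cc(Cl)ccc1Cl)c1ccccc12` likewise stops at a limit, giving > 50000 nM in this assay. Within the data shown here, the single measured step, a step that the two limits leave unreadable from compound 1 to compound 2, is therefore unreadable, and all three values rest together at the limit of > 50000 nM in this assay, at which 3 of the 3 values shown sit.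

Compound 4 `CCc1cccc(CC)c1-n1nncc1CN1C(=O)C2(C(C#N)=C(N)Oc3c(N)cc4nc5ccccc5nc4c32)c2ccccc21` differs from compound 3 in one place on an aromatic nitrogen: 2,6-diethylphenyl in place of 3-bromophenyl on an aromatic nitrogen. No measured step bears on this exchange, and no compound shown has broken through the limit, so no shift beyond the scatter is expected in this assay. The step of a number no higher from compound 3 to compound 4 (the limit leaves the size open) is expected to be flat. Compound 4 is estimated at 50000 nM, within 20000 nM to 120000 nM, and is most likely to be reported again only as a limit.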

Compound 4, half-maximal inhibitory concentration: 16500 nM
Compound 4: middle estimate off by 3.0-fold (0.48 log units), on the high side; the measured number lies below the stated range.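

Exchanging 3-bromophenyl for 2,6-diethylphenyl on the aromatic nitrogen gives an at least 3.0-fold lower number from compound 3 to compound 4 (0.48 log units; beyond the scatter) in this assay, so the aryl group at this position can move the read-out on the core of compound 3. The earlier compounds shown here could not show this: the step between compound 1 and compound 2 cannot be read, and neither 3-methylphenyl nor 2,5-dichlorophenyl, on their shared core, leaves the limit. Compound 4 is the only compound shown with a measured number, while the others remain at the limit: the limit of > 50000 nM in this assay, at which 3 of the 4 values shown sit.

The compounds shown leave open whether a 2-ethylphenyl or a 2,6-dimethylphenyl group on the same nitrogen would also give a measurable number. They also leave open whether 2,6-diethylphenyl would have the same effect on the core of compound 1.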